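The source may hold more compounds than are shown below. What is called first, only, known or untested is meant among the compounds shown, and "the series" means these compounds.

Working notes on the series. Among the measured compounds shown here, in a functional assay on B16-F10 cells (Mus musculus) for inhibition, read by MTT assay, with a stated time of 72 h (a lower number here means a stronger inhibitor, a higher number a weaker inhibitor), compound 1 (`CC1(C)CC(NC(=S)Nc2cccc(C#N)c2)c2cc(Br)ccc2O1`) gives 7000 nM and this is the only number available so far. Compound 2 (`CC1(C)CC(NC(=S)Nc2ccccc2)c2cc(Cl)ccc2O1`) is recorded as "not determined" (no result reported) in this assay with no result behind that entry, so it has no standing on the potency scale and cannot serve as a baseline. The compound awaiting measurement is compound 3 (`CC1(C)CC(NC(=S)Nc2cccc(C#N)c2)c2cc(Cl)ccc2O1`). For the measured compounds named here, the single change leading to it (cyano in place of hydrogen on an aromatic carbon) puts cyano in place of hydrogen on an aromatic carbon, meta to a large group, so that phenyl becomes 3-cyanophenyl. Going by the values given here, the size and direction of this step cannot be read from the data, since compound 2 lacks a number and no measured pair shows the same change. Compound 3 shares the 3-cyanophenyl group with compound 1, so the expectation leans on compound 1 at 7000 nM and anticipates no difference from it beyond the usual scatter in this assay for either direction. For compound 3 the estimated value is 8000 nM with an expected range from 3000 nM to 22000 nM in this reading.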

Compound 3, half-maximal inhibitory concentration: 6000 nM
The estimate for compound 3 lay 1.3-fold (0.12 log units) above the measured number; the range from low to high includes it.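

Chloro in place of bromo on an aromatic carbon gives a 1.2-fold lower number from compound 1 to compound 3 (0.07 log units; within the scatter) in this assay and is the first readable step in the series, so with 3-cyanophenyl held fixed, these two halogens are not told apart in this assay. The step from phenyl to 3-cyanophenyl still cannot be read: compound 2 has no number, and the new value therefore says nothing about what the cyano group contributes at this position. No other measurement available bears on this result.

Still open, going by these compounds, is whether an amine, a carboxylic acid or a methoxy group in place of cyano on the same aromatic carbon would give a number beyond the scatter of the values for compound 1 and compound 3, and how any of these would compare with a measured phenyl reference. Also open, on these data alone, is whether fluoro or a methyl group in place of the chloro of compound 3 would stay within the scatter, since only chloro and bromo have been compared at that place.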